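Clearance notes: ring swaps on the amide nitrogen

A few compounds are considered here, and "the series" means these few. Any claim that something is new, unique, unknown or untested is made for them only; others in the source may bear on it.

Measured so far:
compound 1, `O=C(CN(C(=O)c1ccc(-c2ccccn2)cc1)C1CCCCC1)Nc1cc(F)cc(F)c1`, 5.2 mL.min-1.g-1
compound 2, `O=C(CN(C(=O)c1ccc(-c2ccccn2)cc1)C1CCCOC1)Nc1cc(F)cc(F)c1`, 2.9 mL.min-1.g-1
compound 3, `O=C(CN(CC1CCC1)C(=O)c1ccc(-c2ccccn2)cc1)Nc1cc(F)cc(F)c1`, 2 mL.min-1.g-1

All three share one core and differ only in the group on the amide-type nitrogen. In an in vitro ADME assay on microsomes (Homo sapiens) for metabolic stability (a lower number here means slower removal, a higher number faster removal of the compound), compound 3 gives the lowest of the three numbers; its nearest neighbour is compound 2, with the gap a 1.5-fold lower number from compound 2 to compound 3 (0.16 log units; within the scatter), and its furthest is compound 1, with the gap a 2.6-fold lower number from compound 1 to compound 3 (0.41 log units; beyond the scatter). The step from compound 1 to compound 2, a 1.8-fold lower number from compound 1 to compound 2 (0.25 log units; within the scatter), is the other comparison on hand.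

Compound 4, `O=C(CN(C(=O)c1ccc(-c2ccccn2)cc1)C1CCOC1)Nc1cc(F)cc(F)c1`, has not yet been run in this assay. It differs from compound 3 as follows: oxolan-3-yl in place of cyclobutylmethyl on an amide-type nitrogen. Among the compounds with values here, the entering group is an ether ring, and the closest precedent is the pair in which oxan-3-yl stood on the same nitrogen: compound 2 against compound 3, a step within the scatter. Within the data shown here, the only step beyond the scatter, from compound 1 to compound 3, concerns cyclohexyl, which is not part of the present change. On that basis the step to compound 4 is expected to be small, a 1.4-fold higher number from compound 3 to compound 4 (0.13 log units; within the scatter), if anything toward a slightly higher number, as compound 2 showed. Compound 4 is therefore estimated at 2.7 mL.min-1.g-1, with a range from 1.4 mL.min-1.g-1 to 5 mL.min-1.g-1.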

Compound 4, intrinsic clearance in microsomes: 3.9 mL.min-1.g-1
The estimate for compound 4 lay 1.4-fold (0.16 log units) below the measured number, within the range that was stated.
By their numbers in this assay, from the lowest: compounds 3, 2, 4 and 1 (each within the scatter of the next, the first and the last beyond it).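

In this assay, within the data shown here, oxolan-3-yl on the amide-type nitrogen does not separate from cyclobutylmethyl (a 2.0-fold higher number from compound 3 to compound 4 (0.29 log units; within the scatter)) or from cyclohexyl (a 1.3-fold lower number from compound 1 to compound 4 (0.12 log units; within the scatter)), so compound 4 lies within the scatter of both members of the only pair that stands beyond it. Shrinking the ether ring from oxan-3-yl to oxolan-3-yl also gives no readable change (a 1.3-fold higher number from compound 2 to compound 4 (0.13 log units; within the scatter)), which means ring size among the ether rings is not resolved at this position by these two compounds. Compound 2 and compound 4 now both fall within the scatter of every other compound, so neither ether ring can be placed with the cyclohexyl end or the cyclobutylmethyl end of the set, and the separation between compound 1 and compound 3 remains the single readable difference.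

Still open, on these data alone, is whether an amine, a carboxylic acid or a longer chain on this nitrogen would give a step beyond the scatter from compound 3 or compound 4. Among these compounds, no supporting data are available to explain any of these numbers, so the reason for the one separated pair remains unknown.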